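Isobutyl for 4-fluorophenyl: working notes on the series

The source may hold more compounds than are shown below. What is called first, only, known or untested is meant among the compounds shown, and "the series" means these compounds.

compound 1 `CC1(C)c2[nH]nc(NC(=O)c3ccc(F)cc3)c2CN1C(=O)C1CCN(C2CC2)CC1` gives 380 nM
compound 2 `CC(C)(C)C(=O)N1Cc2c(NC(=O)c3ccc(F)cc3)n[nH]c2C1(C)C` gives 270 nM
compound 3 `CN1CCN(C(=O)N2Cc3c(NC(=O)c4ccc(F)cc4)n[nH]c3C2(C)C)CC1` gives 180 nM
compound 4 `CC(C)CC(=O)Nc1n[nH]c2c1CN(C(=O)C1CCN(C3CC3)CC1)C2(C)C` is not yet measured

In a functional assay on A2780 cells (Homo sapiens) for antiproliferative activity, read by fluorescence, with a stated time of 72 h (a lower number here means a stronger inhibitor, a higher number a weaker inhibitor), compound 1 at 380 nM has the highest of the three numbers. The measured steps are a 1.4-fold lower number from compound 1 to compound 2 (0.15 log units; within the scatter) and a 2.1-fold lower number from compound 1 to compound 3 (0.32 log units; beyond the scatter) and also a 1.5-fold lower number from compound 2 to compound 3 (0.18 log units; within the scatter) in this small set.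

Compound 4 keeps 1-cyclopropylpiperidin-4-yl, and the change is isobutyl in place of 4-fluorophenyl on a carbonyl carbon on a carbonyl carbon whose other neighbour is an amide-type nitrogen. All three measured compounds carry 4-fluorophenyl, and their steps only exchange 1-cyclopropylpiperidin-4-yl, tert-butyl and 4-methylpiperazin-1-yl. Among the compounds with values here, no measured step therefore covers this change, and their small sizes are only a loose guide. A modest move to a higher number is assumed, without direct support from the data. In this assay the expected step is a 1.6-fold higher number from compound 1 to compound 4 (0.20 log units; within the scatter) with low confidence. For compound 4 the estimated value is 600 nM with an expected range from 150 nM to 2400 nM as a deliberately wide span.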

Compound 4, half-maximal inhibitory concentration: 320 nM
Compound 4: middle estimate off by 1.9-fold (0.27 log units), on the high side; the measured number falls inside the stated range.
By their numbers in this assay, from the lowest: compounds 3, 2, 4 and 1 (each within the scatter of the next, the first and the last beyond it).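

In this assay, replacing the ring on the carbonyl carbon whose other neighbour is an amide-type nitrogen gives a 1.2-fold lower number from compound 1 to compound 4 (0.07 log units; within the scatter). Within this one matched pair, 4-fluorophenyl, with its six-membered aromatic ring, and isobutyl, with no ring, cannot be told apart, so the aromatic ring is not needed at this place to keep a number in this range. No measurement among the data bears on why the two groups read alike.

The compounds shown leave open whether isobutyl behaves the same way when 1-cyclopropylpiperidin-4-yl is exchanged for tert-butyl or 4-methylpiperazin-1-yl on the other carbonyl. They also leave open how a longer chain such as n-hexyl, or a chain ending in a primary amine or a carboxylic acid, would read at this place.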